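Extending the chain on the acetyl core toward a propyl analogue

This account rests on a few compounds, and the source may have more. Where it says the series, first, only, none or still open, it means among the compounds named here.

Measured compounds:
- compound 1, `CCCc1c(COc2ccc(-c3nn[nH]n3)cc2)ccc(C=O)c1O`, with 398 nM in a functional assay on ileum (Cavia porcellus) for inhibition of cysteinyl leukotriene receptor (Homo sapiens); on this read-out higher numbers stand for weaker inhibition and lower numbers for stronger inhibition
- compound 2, `CC(=O)c1ccc(COc2ccc(-c3nn[nH]n3)cc2)c(C)c1O`, with 100 nM
- compound 3, `CCc1c(COc2ccc(-c3nn[nH]n3)cc2)ccc(C(C)=O)c1O`, with 12.6 nM

Compound 3 gives the lowest number of the three in this assay; compound 2 lies a step above it and compound 1 is furthest away. Compound 1 and compound 3 differ in two places, so their values can only be set side by side: compound 1 sits well above compound 3. Among the compounds with values here, the one step measured in a single place, a 7.9-fold lower number from compound 2 to compound 3 (0.90 log units; beyond the scatter), concerns a chain lengthened by one carbon and is the step that bears on what follows.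

Compound 4, `CCCc1c(COc2ccc(-c3nn[nH]n3)cc2)ccc(C(C)=O)c1O`, differs from compound 3 by methyl in place of hydrogen on a saturated chain carbon, two bonds along the chain from an aromatic carbon, which is the same change cut one bond further out: ethyl to propyl. Given how far a 7.9-fold lower number from compound 2 to compound 3 (0.90 log units; beyond the scatter) moved, a further but smaller decrease is expected, since a second lengthening need not repeat the first in full. Compound 4 is therefore estimated at 7 nM, within 2.5 nM to 25 nM, an expected step of a 1.8-fold lower number from compound 3 to compound 4 (0.26 log units; within the scatter).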

Compound 4, half-maximal inhibitory concentration: 10 nM
Estimate against measurement, compound 4: 1.4-fold (0.15 log units) below; the measured number falls inside the stated range.
By their numbers in this assay, from the lowest: compounds 4 and 3 (each within the scatter of the next); then compound 2; then compound 1.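

In this assay, the propyl chain of compound 4 and the ethyl chain of compound 3 cannot be told apart (a 1.3-fold lower number from compound 3 to compound 4 (0.10 log units; within the scatter)), so the gain seen from methyl to ethyl does not measurably continue with this further change at this position. The full change from methyl to propyl on the acetyl core remains beyond the scatter (a 10-fold lower number from compound 2 to compound 4 (1.00 log units; beyond the scatter)), and its size is close to that of the methyl-to-ethyl step alone. Within the data shown here, compound 4 also allows the carbonyl carbon to be read in one place for the first time: with propyl held constant, methyl in place of hydrogen there gives the largest of these steps (a 40-fold lower number from compound 1 to compound 4 (1.60 log units; beyond the scatter)). Still open, on these data alone, is whether a butyl group or a longer chain at this position would remain level with ethyl and propyl, or whether an ethyl group on the carbonyl carbon would extend the gain from methyl. Nothing given here accounts for any of these steps.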